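The source may report more compounds than this note shows. Statements on the series, on what has been measured and on what is new or still open speak of the compounds shown alone.

Compound 1 `CC(C)(C)OC(=O)N1CC=C(c2nc(COc3ccc(-n4cnnn4)cc3)cs2)CC1` and compound 2 `CC(C)(C)OC(=O)N1CC=C(c2nc(COc3ccc(-n4cnnn4)cc3F)cs2)CC1` share one core. In a functional assay on isolated protein for agonist activity at Glucose-dependent insulinotropic receptor (Homo sapiens), read by HTRF and cAMP accumulation (a lower number here means that less compound is needed, a higher number that more compound is needed for the effect), compound 1 gives 113 nM, and compound 2 gives 108 nM. For the measured compounds named here, the one measured step, a 1.0-fold lower number from compound 1 to compound 2 (0.02 log units; within the scatter), leaves compound 2 standing level with compound 1 within the scatter. Compound 3 `CC(C)(C)OC(=O)N1CC=C(c2nc(COc3ccc(-n4cnnn4)cc3Cl)cs2)CC1` carries the next change: chloro in place of fluoro on an aromatic carbon. Going by the values given here, the only step that bears on it is that measured one, which stayed within the scatter, so in this assay no step beyond the scatter is expected. For compound 3 the expected step is a 1.2-fold lower number from compound 2 to compound 3 (0.08 log units; within the scatter). Compound 3 is thus estimated at 90 nM, within 35 nM to 250 nM.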

Compound 3, half-maximal effective concentration: 107 nM
The estimate for compound 3 lay 1.2-fold (0.08 log units) below the measured number, within the range that was stated.
By their numbers in this assay, from the lowest: compounds 3, 2 and 1 (each within the scatter of the next).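

In this assay, chloro on this aromatic carbon, ortho to a large group and meta to a 1H-tetrazol-1-yl group, gives a 1.0-fold lower number from compound 2 to compound 3 (0.00 log units; within the scatter) and a 1.1-fold lower number from compound 1 to compound 3 (0.02 log units; within the scatter). Hydrogen, fluoro and chloro therefore stand level at this position, and the larger halogen shows the same tolerance that fluoro alone had suggested. No evidence here says why the number holds. From the compounds shown here alone, whether a methoxy group, an amine or a carboxylic acid on this carbon would keep the number level remains open, as does the effect of chloro elsewhere on the ring.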